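Methyl in place of fluoro on compound 2

The source may report more compounds than this note shows. Statements on the series, on what has been measured and on what is new or still open speak of the compounds shown alone.

Measured so far in a functional assay on HSC-2 cells (Homo sapiens) for cytotoxicity, with a stated time of 24 h; a higher number here means that more compound is tolerated, a lower number that less compound is tolerated:
Compound 1 `COc1cc(/C=C2\CCC/C(=C\c3ccccc3[N+](=O)[O-])C2=O)cc(OC)c1OC`: 5900 nM
Compound 2 `O=C1/C(=C/c2ccc(F)cc2)CCC/C1=C\c1cccc([N+](=O)[O-])c1`: 2200 nM

Of these two numbers, compound 2 holds the lower at 2200 nM, while compound 1 stands higher at 5900 nM, a gap beyond the usual scatter. Compound 3 `Cc1ccc(/C=C2\CCC/C(=C\c3cccc([N+](=O)[O-])c3)C2=O)cc1` has not yet been measured. It keeps the core of compound 2 and changes in one place: methyl in place of fluoro on an aromatic carbon, para to a large group. For the measured compounds named here, no measured pair shows what this swap does in this assay. With only compound 2 at 2200 nM as the starting point, no step beyond the scatter is expected, in either direction. The expected change is a 1.1-fold higher number from compound 2 to compound 3 (0.06 log units; within the scatter). The estimated value for compound 3 is 2500 nM, with an expected range from 900 nM to 7000 nM.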

Compound 3, half-maximal cytotoxic concentration: 17000 nM
Estimate against measurement, compound 3: 6.8-fold (0.83 log units) below; measured number outside the range, above it.
By their numbers in this assay, from the lowest: compound 2; then compound 1; then compound 3.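

In this assay, for the compounds shown here, the exchange of 4-fluorophenyl for 4-methylphenyl gives the first single-place comparison in this set, with a 7.7-fold higher number from compound 2 to compound 3 (0.89 log units; beyond the scatter) for methyl in place of fluoro. This shows that the aromatic carbon para to a large group is not indifferent in this series: replacing one heavy atom with another, with no change in hydrogen-bond donors, hydrogen-bond acceptors or net charge, moves the number beyond the scatter toward more compound tolerated. No measurement at hand explains this step.

On these data alone, with only fluoro and methyl compared here, it remains open whether fluoro lowers the number, methyl raises it, or both contribute; hydrogen, chloro, methoxy or an amine at this carbon would help separate these possibilities. As far as these compounds go, it is also open whether the same exchange gives a similar step on a different core.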